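This account rests on a few compounds, and the source may have more. Where it says the series, first, only, none or still open, it means among the compounds named here.

Working notes on the series, step from compound 3 to compound 4.

Three compounds have numbers in a functional assay on NCI-H460 cells (Homo sapiens) for antiproliferative activity, read by CCK-8 assay, with a stated time of 72 h, tested at 8 uM; a lower number here means a weaker effect, a higher number a stronger effect of the compound at the concentration tested. Within the data shown here, compound 1 `Nc1ccccc1NC(=O)/C=C/c1ccc(Cn2cnc3c(Nc4ccccc4)nc(Cl)nc32)cc1` gives 28.7% and compound 2 `Nc1ccccc1NC(=O)c1ccc(Cn2cnc3c(Nc4ccccc4)nc(Cl)nc32)cc1` gives 77.8%; the single one-place step measured so far, a number 49.1 percentage points higher from compound 1 to compound 2 (beyond the scatter), is the largest movement in the set. Compound 3 `Nc1ccccc1NC(=O)c1ccc(CNc2nc(Cl)nc3c2ncn3Cc2ccccc2)cc1` gives 46.4% and stands second of the three numbers, nearer to compound 1 than to compound 2, with both gaps beyond the scatter.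

Compound 4 `CCCn1cnc2c(NCc3ccc(C(=O)Nc4ccccc4N)cc3)nc(Cl)nc21` differs from compound 3 in one place: ethyl in place of phenyl on a saturated chain carbon bound to an aromatic nitrogen. Among the measured compounds shown here, none of the measured steps bears on this change. For the measured compounds named here, the step from compound 1 to compound 2 concerns the group joining the two aromatic rings on the other side of the shared core, and no pair in the set varies the substituent on the aromatic nitrogen while holding the rest fixed. Compounds 1 and 2 share the benzyl on the aromatic nitrogen with compound 3, so the series gives no reading of what replacing it does.

With nothing to anchor a direction, the working expectation for compound 4 in this assay is no step beyond the scatter, a number 2.4 percentage points lower from compound 3 to compound 4 (within the scatter), and an estimated value of 44% with a broad range from 24% to 64%.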

Compound 4, a percentage reported as inhibition, at one concentration (the size of the read-out at that concentration, not a potency): 39.2%
Compound 4: middle estimate off by 4.8 percentage points, on the high side; the range from low to high includes it.
By their numbers in this assay, from the lowest: compound 1; then compounds 4 and 3 (each within the scatter of the next); then compound 2.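

In this assay, among these compounds, the first reading at this position is a number 7.2 percentage points lower from compound 3 to compound 4 (within the scatter), so ethyl in place of phenyl on a saturated chain carbon bound to an aromatic nitrogen, which also reads as benzyl to propyl, gives a step within the scatter. Unlike a number 49.1 percentage points higher from compound 1 to compound 2 (beyond the scatter), which concerns a different part of the structure and lies beyond the scatter, this change removes a whole six-membered aromatic ring of carbon only without a step beyond the scatter, so in this pair that ring is not needed to keep the read-out at the concentration tested. No supporting observation accompanies this pair, and nothing at hand accounts for the size of the step.

From the compounds shown here alone, with only benzyl and propyl compared here, it remains open whether a longer chain, or a chain ending in an amine or a carboxylic acid, would also stay within the scatter of compound 3. Going by these compounds, it also remains open whether the same exchange would be as quiet when made on compound 2, which gives 77.8% with its different arrangement of groups on the shared core.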